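Halogen on the terminal aryl ring of compound 1

The compounds below may be only part of what the source reports. "The series", "measured", "known", "first", "only" and "open" are said of these compounds alone.

Compound 1 `Cc1ccccc1-c1cccc(COc2ccc([C@H](CC(=O)O)c3nccn3C)cc2)c1` is the parent of this small set. In an assay on CHO cells for agonist activity at Free fatty acid receptor 1 (Homo sapiens), read by luminescence, with a stated time of 20 s, in the presence of a further agent that is not named here (a higher number here means that more compound is needed for the effect, a lower number that less compound is needed), compound 1 gives 89000 nM, the highest of the three numbers measured; compound 3 stands nearest and compound 2 furthest, both beyond the scatter. Compound 2 `Cc1c(Cl)cccc1-c1cccc(COc2ccc([C@H](CC(=O)O)c3nccn3C)cc2)c1` gives 22000 nM, and compound 3 `Cn1ccnc1[C@@H](CC(=O)O)c1ccc(OCc2cccc(-c3ccc(Cl)cc3Cl)c2)cc1` gives 30000 nM. The two measured steps that add chlorine to the outer aryl ring are a 4.0-fold lower number from compound 1 to compound 2 (0.61 log units; beyond the scatter) and a 3.0-fold lower number from compound 1 to compound 3 (0.47 log units; beyond the scatter), both modest and both in the same direction. Between the two chlorinated compounds the step of a 1.4-fold higher number from compound 2 to compound 3 (0.13 log units; within the scatter) is within the scatter.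

Compound 4 `Cc1cc(F)ccc1-c1cccc(COc2ccc([C@H](CC(=O)O)c3nccn3C)cc2)c1` is not yet measured. Its change from compound 1 is fluoro in place of hydrogen on an aromatic carbon. The steps from compound 1 to compound 2 and to compound 3 bear on it, since each places halogen on the same outer ring, and each lowered the number modestly. Fluoro is a single heavy atom, as is the chloro entering in compound 2, so a lowering of similar or somewhat smaller size is expected, giving a 2.0-fold lower number from compound 1 to compound 4 (0.30 log units; within the scatter). Compound 4 is therefore estimated at 45000 nM, with a range from 20000 nM to 100000 nM.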

Compound 4, half-maximal effective concentration: 21000 nM
Beside the measured number, compound 4's estimate is 2.1-fold (0.33 log units) above it; the range from low to high includes it.
By their numbers in this assay, from the lowest: compounds 4, 2 and 3 (each within the scatter of the next); then compound 1.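

In this assay, the step of a 4.2-fold lower number from compound 1 to compound 4 (0.63 log units; beyond the scatter) isolates a single halogen on the outer ring, para to a large group and meta to a methyl group, with the methyl group kept; compound 3, by contrast, differs from compound 1 in more than one place on that ring. The lowering is also not confined to chloro, since fluoro, with its single heavy atom, gives a step beyond the scatter. The three halogenated compounds cannot be told apart, as both a 1.4-fold lower number from compound 3 to compound 4 (0.15 log units; within the scatter) and a 1.0-fold lower number from compound 2 to compound 4 (0.02 log units; within the scatter) lie within the scatter, so 4-fluoro-2-methylphenyl, 3-chloro-2-methylphenyl and 2,4-dichlorophenyl read as equivalent here, and among these four compounds none goes against the lowering on halogen substitution of this ring.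

Nothing available explains why fluoro at this place lowers the number.

Going by these compounds, it remains open whether a methoxy, a trifluoromethyl or an amine at the same place would give a similar step. Also open, on these data alone, is whether chloro at this place, with the methyl group kept, would differ from fluoro.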